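The source may hold more compounds than are shown below. What is called first, only, known or untested is meant among the compounds shown, and "the series" means these compounds.

Measured compounds:
compound 1 `O=C(NO)c1ccc(-c2cn([C@H]3C[C@@H](CO)N(Cc4ccccc4)C3)nn2)cc1` gives < 10%
compound 2 `O=C(NO)c1ccc(-c2cn([C@@H]3C[C@@H](C(=O)O)N(Cc4ccccc4)C3)nn2)cc1` gives < 10%
compound 3 `O=C(NO)c1ccc(-c2cn([C@H]3C[C@H](C(=O)O)N(CCCc4ccccc4)C3)nn2)cc1` gives < 10%

In an assay on Sf9 cells for inhibition of histone deacetylase 11 (Homo sapiens), read by fluorescence, tested at 0.5 uM (a lower number here means less inhibition, a higher number more inhibition at the concentration tested (going by the name of the read-out)), compound 1 gives < 10%, which is a limit of the assay and not a number. Compound 2 likewise returns a limit, < 10%. Compound 3 also returns a limit, < 10%. Among the measured compounds shown here, all three readings therefore coincide, as the limit of < 10% in this assay, at which 3 of the 3 values shown sit, records, and no step between measured compounds can be sized from them. Compound 1 stands where every other measured compound in this assay stands: at the limit, with no numeric reading to compare.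

The step to compound 4 `O=C(NO)c1ccc(-c2cn([C@@H]3C[C@H](CO)N(Cc4ccccc4)C3)nn2)cc1` alters no atom and no bond: the two compounds have the same atoms and bonds and differ only in configuration as drawn: 2 of 2 stereo elements differ (all stereocentres are inverted: mirror images); a stereocentre at a saturated ring carbon is drawn S in compound 1 and R in compound 4; a stereocentre at a saturated ring carbon is drawn S in compound 1 and R in compound 4. For the measured compounds named here, no measured pair shows a mirror-image change, so no size of step can be read from the data. The expectation for this assay is no movement beyond the scatter, a step that the limit leaves unreadable from compound 1 to compound 4 that would keep the reading at or close to the limit. Compound 4 is expected to give 5%, within 0% to 15%.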

Compound 4, a percentage reported as inhibition, at one concentration (the size of the read-out at that concentration, not a potency): 14%
Beside the measured number, compound 4's estimate is 9 percentage points below it, within the range that was stated.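

In this assay compound 4 gives 14%, the only reading shown that is a number and not a limit. Inverting both stereocentres gives a number at least 4 percentage points higher from compound 1 to compound 4 (that floor lies within the scatter), so the data do not establish that configuration moves this read-out, although the change is the only difference in this pair: the fact that compounds 1 and 4 differ only in the configuration as drawn. The series therefore remains close to a single reading, with no step beyond the scatter: the limit of < 10% in this assay, at which 3 of the 4 values shown sit.

As far as these compounds go, it remains open whether a primary amide or an amine in place of the hydroxymethyl group would give a reading clearly above the limit in the configuration of compound 4. From the compounds shown here alone, the effect of a phenethyl group in place of the benzyl group on that same configuration also remains open.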